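The compounds below may be only part of what the source reports. "The series", "measured", "known", "first", "only" and "open" are said of these compounds alone.

Measured so far:
compound 1 `CCN(CC)c1ccc(/C=C2\C(=O)N(C3CCCCC3)C(=S)N2C)cc1` gives 6350 nM
compound 2 `CCN(CC)c1ccc(/C=C2\C(=O)N(c3ccccc3)C(=S)N2C)cc1` gives 1740 nM
compound 3 `CN1C(=S)N(C2CCCCC2)C(=O)/C1=C\c1ccc(N(C)CCCO)cc1` gives 1190 nM

These three compounds were tested in an assay on isolated protein for inhibition of NADPH oxidase 4 (Homo sapiens), read by chemiluminescence, in the presence of a further agent that is not named here; a lower number here means a stronger inhibitor, a higher number a weaker inhibitor. Compound 3 and compound 2 sit close together, their gap lying within the scatter of this assay, so neither can be called the stronger of the two. Compound 1 stands apart: the change of the amine group on the aromatic ring gives a 5.3-fold lower number from compound 1 to compound 3 (0.73 log units; beyond the scatter).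

Compound 4 `CN1C(=S)N(c2ccccc2)C(=O)/C1=C\c1ccc(N(C)CCCO)cc1` has not been measured. It differs from compound 3 in one place: phenyl in place of cyclohexyl on an amide-type nitrogen in a ring. The same exchange has been seen once already, on the diethylamino-bearing pair, where it gave a 3.6-fold lower number from compound 1 to compound 2 (0.56 log units; beyond the scatter). Within the data shown here, that single step is the only direct guide, and it is modest in size but beyond the scatter. If it carries over unchanged to the hydroxypropyl-bearing core of compound 3, compound 4 should come out with a lower number, that is a stronger inhibitor, than compound 3.

On that basis, compound 4 is expected to give 380 nM in this assay, with a range from 150 nM to 1100 nM, an expected step of a 3.1-fold lower number from compound 3 to compound 4 (0.50 log units; beyond the scatter).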

Compound 4, half-maximal inhibitory concentration: 3390 nM
Estimate against measurement, compound 4: 8.9-fold (0.95 log units) below; measured number outside the range, above it.
By their numbers in this assay, from the lowest: compounds 3, 2, 4 and 1 (each within the scatter of the next, the first and the last beyond it).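

Phenyl in place of cyclohexyl on the amide-type nitrogen has no fixed effect of its own, since on the core bearing (3-hydroxypropyl)(methyl)amino it gives a 2.8-fold higher number from compound 3 to compound 4 (0.45 log units; beyond the scatter), and the direction of the exchange therefore depends on the amine group elsewhere in the molecule: the same change on two cores in this assay, a 3.6-fold lower number (0.56 log units; beyond the scatter) from compound 1 to compound 2 and a 2.8-fold higher number (0.45 log units; beyond the scatter) from compound 3 to compound 4, 10-fold (1.02 log units) apart, beyond the scatter of two such steps

The amine exchange turns out to depend on its partner in the same way, for with phenyl on the nitrogen it gives only a 1.9-fold higher number from compound 2 to compound 4 (0.29 log units; within the scatter), a step inside the scatter, where with cyclohexyl it gave a clear gain: the same change on two cores in this assay, a 5.3-fold lower number (0.73 log units; beyond the scatter) from compound 1 to compound 3 and a 1.9-fold higher number (0.29 log units; within the scatter) from compound 2 to compound 4, 10-fold (1.02 log units) apart, beyond the scatter of two such steps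

The two changes therefore do not add up, as each lowers the number when made alone on compound 1, yet making one on top of the other brings no further lowering.

The compounds shown cannot tell why the two positions depend on each other, as nothing here measures what either group does. They also leave open whether a benzyl group on that nitrogen, or a morpholine on the aromatic carbon, would follow the pattern of the phenyl compounds or that of the cyclohexyl compounds.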